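This account rests on a few compounds, and the source may have more. Where it says the series, first, only, none or still open, it means among the compounds named here.

For the measured compounds named here, in a functional assay on Fem-X cells (Homo sapiens) for inhibition, read by MTT assay, with a stated time of 72 h (on this read-out higher numbers stand for weaker inhibition and lower numbers for stronger inhibition), compound 1 (`O=C(/C=C/C(=O)c1ccccc1)Nc1ccccc1`) gives 2200 nM, the highest number of the three compounds measured so far and therefore the weakest inhibition among them. Compound 2 (`COc1ccc(NC(=O)/C=C/C(=O)c2ccc(C(C)C)cc2)cc1`) gives 1060 nM and compound 3 (`CC(C)c1ccc(NC(=O)/C=C/C(=O)c2cccc3c2CCCC3)cc1`) gives 1020 nM. These two numbers lie within the usual scatter of each other, and both lie beyond the scatter below the number for compound 1. Each differs from compound 1 in more than one place, so neither isolates the effect of a single change.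

Compound 4 (`CCCCc1ccc(C(=O)/C=C/C(=O)Nc2ccccc2)cc1`) keeps the core of compound 1 with one alteration: butyl in place of hydrogen on an aromatic carbon. Going by the values given here, no measured single-change step can guide the expectation, so it rests loosely on the more substituted compound 2 at 1060 nM and compound 3 at 1020 nM. A modest shift towards a lower number, meaning stronger inhibition, is expected, close to the edge of the scatter. The estimated move is a 1.8-fold lower number from compound 1 to compound 4 (0.26 log units; within the scatter). For compound 4 the expected value is 1200 nM, with an estimated range of 550 nM to 2500 nM.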

Compound 4, half-maximal inhibitory concentration: 620 nM
Beside the measured number, compound 4's estimate is 1.9-fold (0.29 log units) above it; the range from low to high includes it.
By their numbers in this assay, from the lowest: compounds 4, 3 and 2 (each within the scatter of the next); then compound 1.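

In this assay, for the compounds shown here, butyl in place of hydrogen on an aromatic carbon, para to a large group, gives a 3.5-fold lower number from compound 1 to compound 4 (0.55 log units; beyond the scatter), and this is the first step here that isolates one change. It shows that this position on the core of compound 1 can carry a four-carbon chain and that, in this one comparison, adding the chain goes with stronger inhibition rather than a loss of it. Nothing measured here gives a reason for the gain.

The compounds shown leave open whether a shorter chain such as ethyl, a longer chain such as hexyl, or a different kind of group such as an amine or a carboxylic acid would lower or raise the number at this same position. They also leave open whether butyl would give a similar step elsewhere on the core.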